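The compounds below may be only part of what the source reports. "The series", "measured", "known", "first", "only" and "open" are said of these compounds alone.

Measured in a functional assay on A549 cells (Homo sapiens), read by MTT assay, with a stated time of 72 h; a higher number here means a weaker inhibitor, a lower number a stronger inhibitor:
- compound 1 `CSc1ncnc2c1c(-c1ccccc1)cn2[C@@H]1O[C@H](CO)[C@@H](O)[C@H]1O`: > 20000 nM (a limit)
- compound 2 `CNc1ncnc2c1c(-c1cccs1)cn2[C@@H]1O[C@H](CO)[C@@H](O)[C@H]1O`: > 20000 nM (a limit)
- compound 3 `Cc1nc(N)c2c(-c3ccoc3)cn([C@@H]3O[C@H](CO)[C@@H](O)[C@H]3O)c2n1`: > 20000 nM (a limit)

Compound 3 gives > 20000 nM, which is a limit and not a number. It has no rank within the series, since the data show (the limit of > 20000 nM in this assay, at which 3 of the 3 values shown sit).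

The next compound is compound 4 `Cc1nc(N)c2c(I)cn([C@@H]3O[C@H](CO)[C@@H](O)[C@H]3O)c2n1`, with iodo in place of furan-3-yl on an aromatic carbon.

Going by the values given here, no step between measured compounds is available, so the series gives no direct measure of what such a change does. In this assay the expectation is a small move toward stronger inhibition or none beyond the scatter, and compound 4 may well also return only a limit. For compound 4 the estimated value is 14000 nM, with an expected range of 4000 nM to 20000 nM. This estimate means an expected at least 1.4-fold lower number from compound 3 to compound 4 (0.15 log units; that floor lies within the scatter).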

Compound 4, half-maximal inhibitory concentration: 12100 nM
The estimate for compound 4 lay 1.2-fold (0.06 log units) above the measured number, within the range that was stated.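

In this assay compound 4 is the first compound shown to return a number and not a limit. Iodo in place of furan-3-yl on this aromatic carbon gives an at least 1.6-fold lower number from compound 3 to compound 4 (0.21 log units; that floor lies within the scatter), and only this floor can be read, because of the ceiling of the assay: the limit of > 20000 nM in this assay, at which 3 of the 4 values shown sit. For this pair, then, a five-membered aromatic ring at this place is not needed for a number to be read in this assay, since a single iodo group there is enough.

As far as these compounds go, it remains open whether the number depends on the iodo group itself or only on the loss of furan-3-yl, a question that a chloro or bromo group, or plain hydrogen, on this carbon would address. Also open, from the compounds shown here alone, is how an amine or a longer carbon chain at this place would read.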